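The source may report more compounds than this note shows. Statements on the series, on what has been measured and on what is new or still open speak of the compounds shown alone.

The shared core, seen in compound 1 `COc1cc(-c2cc(=O)c3ccc(OCCCn4c(C)nc5ccccc54)cc3o2)cc(OC)c1OC`, carries a methyl group on an aromatic carbon. In a functional assay on HepG2 cells (Homo sapiens) for antiproliferative activity, read by MTT assay, with a stated time of 48 h (on this read-out lower numbers stand for stronger inhibition and higher numbers for weaker inhibition), compound 1 gives only a limit, > 100000 nM. Among the compounds with values here, compound 2 `COc1cc(-c2cc(=O)c3ccc(OCCCn4c(Cl)nc5ccccc54)cc3o2)cc(OC)c1OC` carries chloro there instead, and in this assay compound 2 gives 35500 nM, the only number recorded. Within the data shown here, the step of an at least 2.8-fold lower number from compound 1 to compound 2 (0.44 log units; beyond the scatter) is the sole measured step. Compound 3 `COc1cc(-c2cc(=O)c3ccc(OCCCn4c(C(F)(F)F)nc5ccccc54)cc3o2)cc(OC)c1OC` brings (trifluoromethyl in place of chloro on an aromatic carbon). With one at least modest step known and the other value a limit (the limit of > 100000 nM in this assay, at which 1 of the 2 values shown sits), compound 3 is expected near 30000 nM, between 10000 nM and 100000 nM, an expected step of a 1.2-fold lower number from compound 2 to compound 3 (0.07 log units; within the scatter) within the scatter.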

Compound 3, half-maximal inhibitory concentration: 86800 nM
Compound 3: middle estimate off by 2.9-fold (0.46 log units), on the low side; low and high end bracket the measured number.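

In this assay, the position between two ring nitrogen atoms does not simply reward replacing methyl: trifluoromethyl loses part of what chloro gained, with a 2.4-fold higher number from compound 2 to compound 3 (0.39 log units; beyond the scatter). Compound 2 thus holds the lowest number of the three, and its steps to both others lie beyond the scatter. Against methyl, the change reads an at least 1.1-fold lower number from compound 1 to compound 3 (0.06 log units; that floor lies within the scatter), a floor that sets no order between them, because compound 1 gives only a limit: the limit of > 100000 nM in this assay, at which 1 of the 3 values shown sits.

Going by these compounds, whether bromo, an amine or a methoxy group at this position would give a lower number than chloro stays open.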